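Urea substituent change on the weakest biaryl analogue

This account rests on a few compounds, and the source may have more. Where it says the series, first, only, none or still open, it means among the compounds named here.

Measured compounds:
compound 1 `COc1ccc(-c2ccc(CN(CCC3CCN(Cc4ccc(C)cc4)CC3)C(=O)NC(C)C)cc2)cc1`, 467 nM
compound 2 `Cc1ccc(CN2CCC(CCN(Cc3ccc(-c4cccc(C#N)c4)cc3)C(=O)NC(C)C)CC2)cc1`, 1010 nM
compound 3 `Cc1ccc(CN2CCC(CCN(Cc3ccc(-c4ccccc4)cc3)C(=O)NC(C)C)CC2)cc1`, 220 nM

In an in vitro functional assay on HEK293 cells for antagonist activity at melanin-concentrating hormone receptor 1 (Homo sapiens), read by GTPgammaS binding, with a stated time of 45 min (a lower number here means a stronger inhibitor, a higher number a weaker inhibitor), compound 2 gives the highest number of the three. Its nearest neighbour is compound 1, a 2.2-fold higher number from compound 1 to compound 2 (0.34 log units; beyond the scatter); its furthest is compound 3, a 4.6-fold lower number from compound 2 to compound 3 (0.66 log units; beyond the scatter). The remaining pair, compound 1 to compound 3, shows a 2.1-fold lower number from compound 1 to compound 3 (0.33 log units; beyond the scatter). All three measured steps alter the outer aromatic ring of the shared core and leave the urea end untouched.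

Compound 4 `Cc1ccc(CN2CCC(CCN(Cc3ccc(-c4cccc(C#N)c4)cc3)C(=O)NC(C)(C)CO)CC2)cc1` is not yet measured. It differs from compound 2 by hydroxymethyl in place of hydrogen on a saturated chain carbon bound to an amide-type nitrogen and two saturated chain carbons. Among the measured compounds shown here, no measured step in this set touches the urea substituent, so nothing here speaks directly for or against a shift in this assay ; the measured steps concern only the aromatic ring and cannot be transferred. For the measured compounds named here, with no bearing step, the expectation is a step of about a 1.0-fold lower number from compound 2 to compound 4 (0.00 log units; within the scatter), that is, none beyond the scatter, with wide uncertainty. Compound 4 is therefore estimated at 1000 nM, in the range 350 nM to 3000 nM.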

Compound 4, antagonist equilibrium constant: 84 nM
Estimate against measurement, compound 4: 12-fold (1.08 log units) above; measured number below the stated range.
By their numbers in this assay, from the lowest: compound 4; then compound 3; then compound 1; then compound 2.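

In this assay, the urea substituent turns out to be a position that responds strongly: hydroxymethyl in place of hydrogen on the saturated chain carbon gives a 12-fold lower number from compound 2 to compound 4 (1.08 log units; beyond the scatter). Among the compounds shown here, that step is larger than the widest step on the outer aromatic ring, a 4.6-fold lower number from compound 2 to compound 3 (0.66 log units; beyond the scatter), so the urea end, untested by the earlier compounds, is the more responsive of the two places in this set. Nothing available accounts for the size of this step.

On these data alone, the step is read only with the 3-cyanophenyl group in place, and its size with the phenyl of compound 3 or the 4-methoxyphenyl of compound 1 remains open. Also open, as far as these compounds go, is how a plain methyl, a carboxylic acid, a primary amine or a longer hydroxyalkyl chain would behave in place of the hydroxymethyl.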